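The source may hold more compounds than are shown below. What is called first, only, known or untested is meant among the compounds shown, and "the series" means these compounds.

The measured compounds and their numbers in an ADME assay for inhibition of phosphatidylcholine:ceramide cholinephosphotransferase 1 (Homo sapiens), read by mass spectrometry, with stated times of 60 min and 30 min (on this read-out lower numbers stand for stronger inhibition and higher numbers for weaker inhibition), are:

compound 1, `CN(Cc1cc(C(F)(F)F)cc(C(F)(F)F)c1)C(=O)c1c(OCCCC2CCN(C(=O)OC3(C)CC3)CC2)c2cccnc2n(C)c1=O`, with 850 nM;
compound 2, `COc1cc(CN(C)C(=O)c2c(OCCCC3CCN(C(=O)OC(C)(C)C)CC3)c3cccnc3n(C)c2=O)cc(OC)c1`, with 10000 nM;
compound 3, `COc1cc(CN(C)C(=O)c2c(OCCCC3CCN(C(=O)OC4(C)CC4)CC3)c3cccnc3n(C)c2=O)cc(OC)c1`, with 18000 nM.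

Compound 3 stands at the highest number of the three. Its nearest neighbour is compound 2, and the step of a 1.8-fold higher number from compound 2 to compound 3 (0.26 log units; within the scatter) is within the scatter, so the two are not separated. Compound 1 lies far lower, and it differs from compound 3 in two places at once: on the 3,5-dimethoxyphenyl ring of compound 3, compound 1 carries trifluoromethyl in place of both methoxy groups. Among the compounds with values here, no single measured step isolates one of these exchanges.

Compound 4, `COc1cc(CN(C)C(=O)c2c(OCCCC3CCN(C(=O)OC4(C)CC4)CC3)c3cccnc3n(C)c2=O)cc(C(F)(F)F)c1`, carries out half of that double exchange: trifluoromethyl in place of methoxy on an aromatic carbon. Within the data shown here, the only guide is the pair compound 1 and compound 3, whose values differ far beyond the scatter. A single exchange is taken to move part of that way, so a lower number than compound 3 is expected in this assay, of a size a 4.5-fold lower number from compound 3 to compound 4 (0.65 log units; beyond the scatter). Compound 4 is therefore estimated at 4000 nM, within a range of 1500 nM to 12000 nM.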

Compound 4, half-maximal inhibitory concentration: 2400 nM
The estimate for compound 4 lay 1.7-fold (0.22 log units) above the measured number; the measured number falls inside the stated range.
By their numbers in this assay, from the lowest: compound 1; then compound 4; then compounds 2 and 3 (each within the scatter of the next).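

In this assay, a single trifluoromethyl in place of methoxy on the aromatic carbon is enough to move the number beyond the scatter (a 7.5-fold lower number from compound 3 to compound 4 (0.88 log units; beyond the scatter)), whereas compound 1 and compound 3 had shown only the two exchanges taken together. The second exchange also counts, as putting methoxy back in place of one trifluoromethyl of compound 1 gives a step beyond the scatter as well (a 2.8-fold higher number from compound 1 to compound 4 (0.45 log units; beyond the scatter)), so across these three compounds neither exchange alone carries the whole change and each one lowers the number in the same direction. Nothing at hand gives a reason for this behaviour of the ring substituents.

The compounds shown leave open whether trifluoromethyl is special at this place or whether a chlorine, a nitrile or a plain hydrogen on the same carbon would give a similar number. Within the data shown here, they also leave open whether tert-butyl and 1-methylcyclopropyl on the carbamate oxygen stay within the scatter of each other when the ring carries trifluoromethyl, as that exchange is seen only on the 3,5-dimethoxyphenyl compounds.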